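The source may hold more compounds than are shown below. What is called first, only, known or untested is meant among the compounds shown, and "the series" means these compounds.

Measured compounds:
- compound 1, `CN1CC[C@H](c2ccc(Cl)cc2)[C@@H](C(=O)OCCCCCc2ccccc2)C1`: 53 nM in an assay on striatum with sodium-dependent dopamine transporter (Rattus norvegicus) as the target; a lower number here means a stronger inhibitor, a higher number a weaker inhibitor
- compound 2, `CCOC(=O)C[C@H]1CN(C)CC[C@@H]1c1ccc(Cl)cc1`: 79 nM in this assay

Among the compounds with values here, compound 2 carries the highest of the two numbers so far, but its nearest neighbour, compound 1, sits within the usual scatter of it, so the two readings cannot be told apart. Within the data shown here, no step between two measured compounds differing in one place exists, so no measured reference for the size of a single change is available.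

Compound 3, `CN1CC[C@H](c2ccc(Cl)cc2)[C@@H](CCCF)C1`, is not yet measured. It differs from compound 2 by 2-fluoroethyl in place of ethoxycarbonyl on a saturated chain carbon bound to a saturated ring carbon. Among the measured compounds shown here, with no comparable measured step, the expected step from compound 2 to compound 3 is estimated as a 1.5-fold higher number from compound 2 to compound 3 (0.18 log units; within the scatter), modest and towards a higher number, but with wide uncertainty in either direction. Compound 3 is therefore expected at about 120 nM, with a range from 30 nM to 500 nM.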

Compound 3, inhibition constant: 43 nM
Beside the measured number, compound 3's estimate is 2.8-fold (0.45 log units) above it; the range from low to high includes it.
By their numbers in this assay, from the lowest: compounds 3, 1 and 2 (each within the scatter of the next).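

In this assay, within the data shown here, this is the first single change that can be read, and it comes out as a 1.8-fold lower number from compound 2 to compound 3 (0.26 log units; within the scatter). On a saturated chain carbon bound to a saturated ring carbon, ethoxycarbonyl, with its carbonyl and hydrogen-bond acceptors, and 2-fluoroethyl, with no hydrogen-bond acceptors, therefore give readings that cannot be told apart, so for this pair the carbonyl and ester oxygens are not needed to hold the reading. Nothing available bears on why the two readings stand so close.

Still open, going by these compounds, is whether other groups at this place, such as a carboxylic acid, an amine or a longer chain, would also leave the reading within the scatter. One pair also leaves open whether this tolerance holds on any other core.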